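The compounds below may be only part of what the source reports. "The series", "measured", "known", "first", "only" and "open" are said of these compounds alone.

Compound 3 `CC(C)(C)c1ccc(NC(=O)c2ccc(-c3ncccc3N(S(C)(=O)=O)S(C)(=O)=O)cc2)cc1` gives 0.4 nM in a functional assay for antagonist activity at transient receptor potential cation channel subfamily V member 1 (Rattus norvegicus) (on this read-out higher numbers stand for weaker inhibition and lower numbers for stronger inhibition), and holds the lowest number of the three measured. Compound 1 `CC(C)(C)c1ccc(NC(=O)c2ccc(-c3ncccc3F)cc2)cc1` gives 1 nM. Compound 2 `CCS(=O)(=O)Nc1cccnc1-c1ccc(C(=O)Nc2ccc(C(C)(C)C)cc2)cc1` gives 4 nM. Both steps down to compound 3 lie beyond the scatter: a 2.5-fold lower number from compound 1 to compound 3 (0.40 log units; beyond the scatter) and a 10-fold lower number from compound 2 to compound 3 (1.00 log units; beyond the scatter). Compound 4 `CC(C)(C)c1ccc(NC(=O)c2ccc(-c3ncccc3C(=O)O)cc2)cc1` differs from compound 3 in one place: carboxy in place of bis(methylsulfonyl)amino on an aromatic carbon. All measured steps sit at this same position and run both ways: a 4.0-fold higher number from compound 1 to compound 2 (0.60 log units; beyond the scatter), whereas a 10-fold lower number from compound 2 to compound 3 (1.00 log units; beyond the scatter). For the measured compounds named here, no measured compound carries a carboxy there, so the bearing is indirect. Given that compound 3 gives 0.4 nM, the lowest number, the change to a carboxy is expected to raise the number modestly, a 13-fold higher number from compound 3 to compound 4 (1.10 log units; beyond the scatter). Compound 4 is therefore estimated at 5 nM, within a range from 1 nM to 30 nM.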

Compound 4, half-maximal inhibitory concentration: 560 nM
Compound 4: middle estimate off by 110-fold (2.05 log units), on the low side; the whole stated range lies below it.
By their numbers in this assay, from the lowest: compound 3; then compound 1; then compound 2; then compound 4.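

In this assay the carboxy group brings large steps at this position, with a 1400-fold higher number from compound 3 to compound 4 (3.15 log units; beyond the scatter) and a 140-fold higher number from compound 2 to compound 4 (2.15 log units; beyond the scatter) and a 560-fold higher number from compound 1 to compound 4 (2.75 log units; beyond the scatter) from a single change on the same aromatic carbon. Fluoro, (ethylsulfonyl)amino and bis(methylsulfonyl)amino had shifted the number only modestly, so the position is less permissive than those three compounds suggested, and compound 4 stands highest of the four. Nothing shown gives a measured explanation for this. Going by these compounds, it remains open whether the high number belongs to the carboxylic acid alone or would also come with its methyl ester, a primary carboxamide or a hydroxymethyl group in the same place.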